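The source may report more compounds than this note shows. Statements on the series, on what has been measured and on what is new or still open speak of the compounds shown alone.

Working notes on the sulfonylpiperazine acetanilide series

Two compounds of this series carry measurements. Compound 1 `O=C(CN1CCN(S(=O)(=O)c2ccc(F)cc2)CC1)Nc1ccccc1` bears a fluorine on the aryl sulfonyl ring and none on the anilide; in an in vitro assay on HEK ts201 cells for negative allosteric modulation of Neuronal acetylcholine receptor; alpha4/beta2 (Homo sapiens), read by fluorescence and calcium flux, with a stated time of 1.5 s (a higher number here means a weaker inhibitor, a lower number a stronger inhibitor), compound 1 gives 14900 nM. Compound 2 `O=C(CN1CCN(S(=O)(=O)c2ccccc2F)CC1)Nc1ccccc1F` carries a fluorine on each of the two outer rings; in this assay compound 2 gives 8000 nM. Among the measured compounds shown here, the two numbers lie within the usual scatter of one another, so nothing separates compound 1 from compound 2 on present evidence, and no step between measured compounds is available to guide a prediction.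

Compound 3 `O=C(CN1CCN(S(=O)(=O)c2cccnc2)CC1)Nc1ccccc1F` is the next target. The change from compound 2 is pyridin-3-yl in place of 2-fluorophenyl on a sulfonyl sulfur. For the measured compounds named here, no measured pair tests this kind of exchange on the sulfonyl ring, so the expected step from compound 2 to compound 3 is set at a 1.4-fold higher number from compound 2 to compound 3 (0.14 log units; within the scatter), which is not expected to exceed the scatter. Compound 3 is therefore estimated at 11000 nM in this assay, with a range from 4000 nM to 30000 nM.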

Compound 3, half-maximal inhibitory concentration: 20300 nM
Estimate against measurement, compound 3: 1.8-fold (0.27 log units) below; measured number inside the range.
By their numbers in this assay, from the lowest: compounds 2, 1 and 3 (each within the scatter of the next, the first and the last beyond it).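

In this assay, the position on the sulfonyl sulfur now gives a step beyond the scatter: pyridin-3-yl in place of 2-fluorophenyl makes compound 3 the weaker inhibitor of the pair (a 2.5-fold higher number from compound 2 to compound 3 (0.40 log units; beyond the scatter)). Among the compounds shown here, the earlier compounds offered no single-place comparison, so this is the first sign that the ring on the sulfonyl sulfur affects the number, though the step is modest and rests on one pair. Nothing at hand accounts for the size or direction of this step.

A plain phenyl on the sulfonyl sulfur, with the anilide of compound 2 kept, would separate the loss of the fluorine from the entry of the ring nitrogen. Also open, as far as these compounds go, is how an amine or a carboxylic acid on this ring would move the number.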